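Adding trifluoromethyl to compound 1

This account rests on a few compounds, and the source may have more. Where it says the series, first, only, none or still open, it means among the compounds named here.

Compound 1 `O=C1/C(=C\c2ccccc2)c2c(ncn2COCc2ccccc2)CCN1Cc1ccccc1`: 13900 nM
Compound 2 `Cc1ccccc1CN1CCc2ncn(COCc3ccccc3)c2/C(=C/c2ccccc2)C1=O`: 53300 nM

In a functional assay on HepG2 cells (Homo sapiens) for inhibition, read by MTT assay, with a stated time of 72 h (a lower number here means a stronger inhibitor, a higher number a weaker inhibitor), compound 1 holds the lower of the two numbers, at 13900 nM. Compound 3 `O=C1/C(=C\c2ccc(C(F)(F)F)cc2)c2c(ncn2COCc2ccccc2)CCN1Cc1ccccc1` differs from it by trifluoromethyl in place of hydrogen on an aromatic carbon, with trifluoromethyl in place of hydrogen on an aromatic carbon. Within the data shown here, the only measured step is a 3.8-fold higher number from compound 1 to compound 2 (0.58 log units; beyond the scatter), which placed a methyl in place of hydrogen on an aromatic carbon. That is a different group and only a loose guide. A step no larger than this is expected in this assay, with its direction open. The estimated step is a 1.2-fold higher number from compound 1 to compound 3 (0.06 log units; within the scatter). For compound 3 the expected value is 16000 nM, within an estimated range of 6000 nM to 43000 nM.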

Compound 3, half-maximal inhibitory concentration: 51400 nM
Beside the measured number, compound 3's estimate is 3.2-fold (0.51 log units) below it; measured number outside the range, above it.
By their numbers in this assay, from the lowest: compound 1; then compounds 3 and 2 (each within the scatter of the next).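

In this assay the position on an aromatic carbon para to a large group proves sensitive, since trifluoromethyl there gives a 3.7-fold higher number from compound 1 to compound 3 (0.57 log units; beyond the scatter) and so takes inhibition away from the level of compound 1. The earlier step showed such a loss only for methyl at a different aromatic carbon, and now both single changes shown from compound 1 weaken it, with neither going against this. Nothing measured here accounts for the loss.

Going by these compounds, whether a fluorine atom, a methoxy group or an amine at this same position would also weaken inhibition stays open. So does whether trifluoromethyl elsewhere on this ring would.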